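A Fluoro Swapped for Hydrogen on a Sulfamoyl Compound

This account rests on a few compounds, and the source may have more. Where it says the series, first, only, none or still open, it means among the compounds named here.

So far, two compounds with the shared core have been tested in an ADME assay on LLC-MK2 cells (Macaca mulatta) for cytotoxicity, read by spectrophotometry and crystal violet staining, with a stated time of 4 days; a higher number here means that more compound is tolerated, a lower number that less compound is tolerated. Compound 1 (`CC(C)n1ncc2c(C(=O)Nc3ccc(F)cc3)cc(-c3cccs3)nc21`) gives > 200000 nM as its reading, which is a limit of the assay and not a number. Going by the values given here, compound 2 (`CC(C)n1ncc2c(C(=O)Nc3cc(S(N)(=O)=O)ccc3F)cc(-c3cccs3)nc21`) gives 25000 nM as its reading, the only actual number available, so it has no numerical neighbour to be ranked against.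

Compound 3 (`CC(C)n1ncc2c(C(=O)Nc3cccc(S(N)(=O)=O)c3)cc(-c3cccs3)nc21`) has not yet been measured. It differs from compound 2 in one place, with hydrogen in place of fluoro on an aromatic carbon, ortho to a large group and para to a sulfamoyl group. The sulfamoyl group itself stays. Among the compounds with values here, no measured pair shows what this change does, so any forecast is anchored on compound 2 at 25000 nM as the sole starting point. The estimated 1.2-fold higher number from compound 2 to compound 3 (0.08 log units; within the scatter) is expected to stay within the usual scatter of this assay and to have no firm direction. For compound 3 the expected value is 30000 nM with an estimated range from 10000 nM to 100000 nM in this measurement.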

Compound 3, half-maximal cytotoxic concentration: 25000 nM
Beside the measured number, compound 3's estimate is 1.2-fold (0.08 log units) above it; the measured number falls inside the stated range.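

In this assay, going by these compounds alone, the fluoro on the aromatic carbon para to the sulfamoyl group can be replaced by hydrogen with no change at the digits printed from compound 2 to compound 3 (within the scatter), so this is the first measured pair to show that, with the sulfamoyl group in place, this swap leaves the reading unmoved. Within the data shown here, the second step, with 3-sulfamoylphenyl in place of 4-fluorophenyl on an amide-type nitrogen, gives an at least 8.0-fold lower number from compound 1 to compound 3 (0.90 log units; beyond the scatter), and it is the first to set a compound carrying the sulfamoyl group against compound 1 in one change, without fluoro on the ring of compound 3 to blur the comparison. The true size of that step cannot be given because compound 1 stands at a limit of the assay and not at a number: the limit of > 200000 nM in this assay, at which 1 of the 3 values shown sits.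

The compounds shown leave open whether the lower number follows the sulfamoyl group itself, its place on the ring, or the loss of the 4-fluoro group. Going by these compounds, what a carboxylic acid or an amine would give at the position of the sulfamoyl group, and whether the fluoro swap would stay as quiet beside either of them, also remains open.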